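Chloro for Methyl: an Estimate for Compound 4

The source may report more compounds than this note shows. Statements on the series, on what has been measured and on what is new or still open speak of the compounds shown alone.

Among the measured compounds shown here, compound 3 `COC(=O)[C@@]1(C)CCC=C2[C@@H]1CC[C@@H](C)[C@]2(C)Cc1c[nH]c2c(C)cccc12` gives 8000 nM in a functional assay on HBL-100 cells (Homo sapiens) for inhibition, read by sulforhodamine B assay, with a stated time of 48 h (on this read-out higher numbers stand for weaker inhibition of growth and lower numbers for stronger inhibition of growth), the second highest of the three numbers so far. Its nearest neighbour is compound 2 `COC(=O)[C@@]1(C)CCC=C2[C@@H]1CC[C@@H](C)[C@]2(C)Cc1c[nH]c2ccc(F)cc12`, which in this assay gives 4800 nM, a gap within the scatter; furthest is compound 1 `COC(=O)[C@@]1(C)CCC=C2[C@@H]1CC[C@@H](C)[C@]2(C)Cc1c[nH]c2ccc(C)cc12`, which gives 18000 nM, a gap beyond the scatter. Compound 4 `COC(=O)[C@@]1(C)CCC=C2[C@@H]1CC[C@@H](C)[C@]2(C)Cc1c[nH]c2c(Cl)cccc12` differs from compound 3 in one place: chloro in place of methyl on an aromatic carbon, on an aromatic carbon of a six-membered aromatic ring of carbon only, ortho to a fused ring. For the measured compounds named here, the only measured step that bears on this is a 3.8-fold lower number from compound 1 to compound 2 (0.57 log units; beyond the scatter), a halogen in place of methyl at another aromatic carbon, which lowered the number. The chloro for methyl exchange is of the same kind, so a modest lowering is expected, although the different position and the larger halogen leave the size uncertain. Compound 4 is therefore expected to give 4500 nM, within a range from 1500 nM to 14000 nM. The expected step is a 1.8-fold lower number from compound 3 to compound 4 (0.25 log units; within the scatter).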

Compound 4, concentration for 50% growth inhibition: 19000 nM
Estimate against measurement, compound 4: 4.2-fold (0.63 log units) below; the whole stated range lies below it.
By their numbers in this assay, from the lowest: compounds 2 and 3 (each within the scatter of the next); then compounds 1 and 4 (each within the scatter of the next).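

In this assay, chloro in place of methyl on this aromatic carbon, ortho to a fused ring, gave a 2.4-fold higher number from compound 3 to compound 4 (0.38 log units; beyond the scatter) and so moved the number the opposite way to a 3.8-fold lower number from compound 1 to compound 2 (0.57 log units; beyond the scatter) where fluoro replaced methyl at another aromatic carbon. A halogen in place of methyl therefore has no single direction across these compounds, and since the two steps differ in both the halogen and the position, the two changes cannot be told apart here. Nothing measured here accounts for the rise at this position.

Going by these compounds, whether fluoro on this same carbon would raise the number as chloro does or lower it as in the step to compound 2 remains open. On these data alone, how a methoxy group, an amine or a carboxylic acid would read at this carbon also remains open.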